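The source may report more compounds than this note shows. Statements on the series, on what has been measured and on what is new or still open speak of the compounds shown alone.

Measured so far:
compound 1 `CCCC(=O)C1=C(C)NC(=O)NC1c1ccoc1`: 22%
compound 2 `CC1=C(C(=O)NC(C)C)C(c2ccoc2)NC(=O)N1`: 3%

Within the data shown here, in an assay on membranes from HEK293 cells for displacement of a labelled ligand from adenosine receptor A2b (Homo sapiens), read by scintillation counting, with a stated time of 30 min, tested at 1 uM (a lower number here means less inhibition, a higher number more inhibition at the concentration tested (going by the name of the read-out)), compound 2 stands lowest of the two numbers; its nearest neighbour is compound 1, and the one measured step is a number 19 percentage points lower from compound 1 to compound 2 (beyond the scatter). Compound 3 `CCN(CC)C(=O)C1=C(C)NC(=O)NC1c1ccoc1` differs from compound 2 by diethylamino in place of isopropylamino on a carbonyl carbon. Among the measured compounds shown here, the measured step put isopropylamino in place of propyl on a carbonyl carbon, which is a different kind of change; no measured step compares two amino groups at that carbon, so nothing here points to a movement beyond the scatter, and the expected step is a number 2 percentage points higher from compound 2 to compound 3 (within the scatter). Compound 3 is therefore estimated at 5%, within 0% to 20%.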

Compound 3, a percentage reported as inhibition, at one concentration (the size of the read-out at that concentration, not a potency): 12%
The estimate for compound 3 lay 7 percentage points below the measured number, within the range that was stated.
By their numbers in this assay, from the lowest: compounds 2, 3 and 1 (each within the scatter of the next, the first and the last beyond it).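

Swapping isopropylamino for diethylamino on this carbonyl carbon removes the amide hydrogen and adds one carbon, yet the result is a number 9 percentage points higher from compound 2 to compound 3 (within the scatter). Diethylamino also cannot be separated from propyl at this position, with a number 10 percentage points lower from compound 1 to compound 3 (within the scatter), whereas isopropylamino could be, with a number 19 percentage points lower from compound 1 to compound 2 (beyond the scatter). Nothing available explains these numbers. Still open, on these data alone, is how a ring amine such as piperidine or morpholine, or a longer chain such as hexyl, would read on this carbonyl carbon.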